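A few compounds are considered here, and "the series" means these few. Any claim that something is new, unique, unknown or untested is made for them only; others in the source may bear on it.

Working notes on the series. The shared core carries a chain from an oxygen on the aromatic ring, and the three measured compounds differ only in the group on that chain. Compound 1 `O=C1N=C(O)S/C1=C\c1ccc(OCCc2ccccn2)cc1Cl` gives 8920 nM in an assay for inhibition of 15-hydroxyprostaglandin dehydrogenase [NAD(+)] (Homo sapiens), read by fluorescence and spectrophotometry; on this read-out lower numbers stand for stronger inhibition and higher numbers for weaker inhibition. Compound 2 `O=C1N=C(O)S/C1=C\c1ccc(OCc2ccccc2)cc1Cl` gives 487 nM in this assay, and compound 3 `O=C1N=C(O)S/C1=C\c1ccc(OCCc2ccccc2)cc1Cl` gives 178 nM in this assay. Compound 3 stands lowest of the three, with the step of a 2.7-fold lower number from compound 2 to compound 3 (0.44 log units; beyond the scatter) and the step of a 50-fold lower number from compound 1 to compound 3 (1.70 log units; beyond the scatter) both beyond the scatter, so on these numbers it is the strongest inhibitor in the set; the step of an 18-fold lower number from compound 1 to compound 2 (1.26 log units; beyond the scatter) is large as well.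

Compound 4 `O=C1N=C(O)S/C1=C\c1ccc(OCCCCc2ccccc2)cc1Cl` has not been measured. Its change from compound 3 is phenethyl in place of phenyl on a saturated chain carbon, two bonds along the chain from an oxygen on an aromatic ring. Of the measured steps only a 2.7-fold lower number from compound 2 to compound 3 (0.44 log units; beyond the scatter) bears on this directly, as it is the only one that lengthens the chain without replacing the pyridin-2-yl group; it was modest. That step does not show whether further lengthening continues in the same direction, and nothing in the set tests a chain as long as the phenethyl group on this carbon, so for this assay a small step, within or near the scatter, is expected in either direction. The estimate for compound 4 is 250 nM, from 70 nM to 900 nM, an expected step of a 1.4-fold higher number from compound 3 to compound 4 (0.15 log units; within the scatter) from compound 3.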

Compound 4, half-maximal inhibitory concentration: 81 nM
Compound 4: the middle estimate sits 3.1-fold (0.49 log units) above what was measured; the range from low to high includes it.
By their numbers in this assay, from the lowest: compound 4; then compound 3; then compound 2; then compound 1.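

In this assay, extending the group on this saturated chain carbon from phenyl to phenethyl still pays: a 2.2-fold lower number from compound 3 to compound 4 (0.34 log units; beyond the scatter) is beyond the scatter and runs the same way as a 2.7-fold lower number from compound 2 to compound 3 (0.44 log units; beyond the scatter), so the compounds ending in an unsubstituted phenyl ring now form a run of three in which the number falls as the chain grows. Compound 1 stands outside this run, and a 110-fold lower number from compound 1 to compound 4 (2.04 log units; beyond the scatter) widens the gap between its pyridin-2-yl end and the carbon-only ring at the end of the longer chain. Nothing available explains why either change moves the number.

For the compounds shown here, whether a chain longer than the one in compound 4 continues the fall or reverses it remains open. Also open, as far as these compounds go, is how a pyridin-2-yl, an amine or a carboxylic acid at the end of that longer chain would compare with its phenyl ring.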